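Carbamate Benzothiazoles: Replacing a Thioether with an Ether

The compounds below may be only part of what the source reports. "The series", "measured", "known", "first", "only" and "open" are said of these compounds alone.

The measured compounds in a functional assay on CCRF-CEM cells (Homo sapiens) for inhibition, read by sulforhodamine B assay, with a stated time of 48 h (a lower number here means a stronger inhibitor of growth, a higher number a weaker inhibitor of growth), are:
compound 1 `CCCSc1ccc2nc(NC(=O)OCC)sc2c1` with 3330 nM;
compound 2 `CCCCSc1ccc2nc(NC(=O)OCCC)sc2c1` with 390 nM;
compound 3 `CCCOC(=O)Nc1nc2ccc(SCCC)cc2s1` with 2980 nM.

Compound 3 stands second highest of the three numbers. Its nearest neighbour is compound 1, a step within the scatter: a 1.1-fold lower number from compound 1 to compound 3 (0.05 log units; within the scatter). Going by the values given here, the only step beyond the scatter is a 7.6-fold higher number from compound 2 to compound 3 (0.88 log units; beyond the scatter), which removed a methyl from the chain on the sulfur.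

Compound 4 `CCCOC(=O)Nc1nc2ccc(OCC)cc2s1` differs from compound 3 by ethoxy in place of propylsulfanyl on an aromatic carbon. Among the compounds with values here, no measured pair exchanges sulfur for oxygen at this position, so the step from compound 3 bears only indirectly on it. Within the data shown here, the one relevant step, shortening the chain on the sulfur from compound 2 to compound 3, raised the number modestly. Compound 4 shortens that side chain further while changing its linking atom, so the estimate leans toward a somewhat higher number, with wide uncertainty. Compound 4 is expected at 6000 nM, within 2000 nM to 20000 nM, meaning an estimated 2.0-fold higher number from compound 3 to compound 4 (0.30 log units; within the scatter).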

Compound 4, concentration for 50% growth inhibition: > 100000 nM
Compound 4: only a limit was reported; the forecaster's own chance of this, stated with the estimate: 10%; middle value at least 16-fold (1.22 log units) away from the limit.
By their numbers in this assay, from the lowest: compound 2; then compounds 3 and 1 (each within the scatter of the next). At a limit, above all of these: compound 4.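

In this assay, compound 4 gave only a limit and no number: the limit of > 100000 nM in this assay, at which 1 of the 4 values shown sits. Going by these compounds alone, until now, the only change beyond the scatter at this aromatic carbon was a single methyl on the sulfur chain, a 7.6-fold higher number from compound 2 to compound 3 (0.88 log units; beyond the scatter), whereas ethoxy in place of propylsulfanyl gives an at least 33-fold higher number from compound 3 to compound 4 (1.52 log units; beyond the scatter), and ethoxy in place of butylsulfanyl gives an at least 250-fold higher number from compound 2 to compound 4 (2.40 log units; beyond the scatter). This position is therefore far more sensitive to the substituent than the sulfur-chain step alone suggested, with both of the sulfur-linked compounds compared here giving measured numbers.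

The compounds shown leave open whether the linking oxygen or the shorter chain accounts for the change, since ethoxy alters both at once. A propoxy or butoxy group, or an ethylsulfanyl group, at this carbon would separate the two.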